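The source may hold more compounds than are shown below. What is called first, only, known or untested is meant among the compounds shown, and "the series" means these compounds.

Working notes on the shared core of compound 1 `Cc1ccc(N2C(=O)C=CC2OCC(F)(F)F)cc1`. For the measured compounds named here, in a functional assay on MDA-MB-231 cells (Homo sapiens) for inhibition (on this read-out lower numbers stand for stronger inhibition and higher numbers for weaker inhibition), compound 1 gives 15800 nM, the highest number among the three measured members. Compound 2 `O=C1C=CC(OCC(F)(F)F)N1c1cc(F)cc(F)c1` gives 7840 nM, which lies within the scatter of compound 1; compound 3 `O=C1C=CC(OCC(F)(F)F)N1c1ccc(F)c(Cl)c1` gives 3440 nM, a number beyond the scatter below compound 1. Halogen substitution on the aromatic ring thus goes along with lower numbers in compounds 2 and 3, but no single-change pair is available to size that effect. Compound 4 `O=C1C=CC(OCC(F)(F)F)N1c1ccc(C(F)(F)F)cc1` carries trifluoromethyl in place of methyl on an aromatic carbon. Given the lower number of compound 3 at 3440 nM, a small step toward lower numbers is expected from compound 1 to compound 4, a 2.1-fold lower number from compound 1 to compound 4 (0.32 log units; beyond the scatter), possibly not beyond the scatter. Compound 4 is estimated at 7500 nM, within 2500 nM to 22000 nM, pending measurement.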

Compound 4, half-maximal inhibitory concentration: 2300 nM
Compound 4: the middle estimate sits 3.3-fold (0.51 log units) above what was measured; the measured number lies below the stated range.
By their numbers in this assay, from the lowest: compounds 4 and 3 (each within the scatter of the next); then compounds 2 and 1 (each within the scatter of the next).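

For the compounds shown here, on an aromatic carbon para to a large group, trifluoromethyl in place of methyl gives the first single-change step: in this assay, the change gives a 6.9-fold lower number from compound 1 to compound 4 (0.84 log units; beyond the scatter). With the rest of the shared core held constant, this position is shown to affect the read-out by more than the scatter. Nothing measured here accounts for the step. From the compounds shown here alone, whether a nitrile or an amine on the same carbon would give a lower or a higher number remains open. So does whether the step would hold with a halogen elsewhere on the aromatic ring.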